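This account rests on a few compounds, and the source may have more. Where it says the series, first, only, none or still open, it means among the compounds named here.

Compound 1 `Cc1ccc(NS(=O)(=O)c2ccc(N3CCNC3=O)cc2)cc1`: 480 nM
Compound 2 `O=C1NCCN1c1ccc(S(=O)(=O)Nc2ccc(Cl)cc2)cc1`: 220 nM
Compound 3 `O=C1NCCN1c1ccc(S(=O)(=O)Nc2ccc(OC(F)F)cc2)cc1`: 650 nM

In a functional assay on HT-29 cells (Homo sapiens) for antiproliferative activity, read by sulforhodamine B assay, with a stated time of 48 h (a lower number here means a stronger inhibitor, a higher number a weaker inhibitor), compound 3 gives 650 nM. It cannot be separated from compound 1, given a 1.4-fold higher number from compound 1 to compound 3 (0.13 log units; within the scatter), but it stands apart from compound 2, given a 3.0-fold higher number from compound 2 to compound 3 (0.47 log units; beyond the scatter).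

Compound 4 `CCCCOc1ccc(NS(=O)(=O)c2ccc(N3CCNC3=O)cc2)cc1` has not yet been measured. Its structural change is butyl in place of difluoromethyl on an oxygen on an aromatic ring.

Among the compounds with values here, no measured step covers this exact swap, and the series holds no measured compound with a butyl group. The nearest guides are the exchanges of a group on an aromatic carbon, where the remaining step is a 2.2-fold lower number from compound 1 to compound 2 (0.34 log units; beyond the scatter). As far as these compounds go, these three steps are at most modest, so a large change is not expected here, although the longer chain is untested. The expected result is no clear shift beyond the scatter, given as a 1.2-fold higher number from compound 3 to compound 4 (0.06 log units; within the scatter). The estimate for compound 4 is 750 nM, with an expected range of 230 nM to 2500 nM.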

Compound 4, half-maximal inhibitory concentration: 630 nM
The estimate for compound 4 lay 1.2-fold (0.08 log units) above the measured number, and the stated range covers the measured number.
By their numbers in this assay, from the lowest: compound 2; then compounds 1, 4 and 3 (each within the scatter of the next).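

Butyl in place of difluoromethyl on the oxygen gives no separable change in this assay (a 1.0-fold lower number from compound 3 to compound 4 (0.01 log units; within the scatter)), so at this place two quite different groups on the oxygen, one fluorinated and one a plain chain, read alike. The butoxy group also cannot be told from methyl on the aromatic carbon (a 1.3-fold higher number from compound 1 to compound 4 (0.12 log units; within the scatter)), whereas chloro remains apart from it (a 2.9-fold higher number from compound 2 to compound 4 (0.46 log units; beyond the scatter)), so among these compounds only compound 2 stands out, and neither oxygen-linked group matches it. Nothing available explains these numbers.

Open, as far as these compounds go, is whether a longer chain than butyl, an amine or a carboxylic acid at this place would move the number beyond the scatter. Also open, from the compounds shown here alone, is whether any other halogen, such as bromo, would match chloro here.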